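A few compounds are considered here, and "the series" means these few. Any claim that something is new, unique, unknown or untested is made for them only; others in the source may bear on it.

Compound 1 `COc1ccc(C2C(C#N)=C(N)N(c3cc(OC)c(OC)c(OC)c3)C3=C2C(=O)CC(C)(C)C3)cc1` gives 15% in a functional assay on Ehrlich cells (Mus musculus) for cytotoxicity, tested at 100 ug/mL (on this read-out higher numbers stand for a stronger effect at the one concentration tested and lower numbers for a weaker effect), the lowest of the three numbers measured. Compound 2 `COc1cc(N2C(N)=C(C#N)C(c3c(OC)ccc4ccccc34)C3=C2CC(C)(C)CC3=O)cc(OC)c1OC` gives 30% in this assay, and compound 3 `COc1cc(N2C(N)=C(C#N)C(c3ccc(OC)c4ccccc34)C3=C2CC(C)(C)CC3=O)cc(OC)c1OC` gives 40% in this assay. Both steps away from compound 1 enlarge the 4-methoxyphenyl group into a naphthalene: a number 15 percentage points higher from compound 1 to compound 2 (beyond the scatter) and a number 25 percentage points higher from compound 1 to compound 3 (beyond the scatter).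

Compound 4 `COc1cc(N2C(N)=C(C#N)C(c3ccc(O)cc3)C3=C2CC(C)(C)CC3=O)cc(OC)c1OC` differs from compound 1 only by hydrogen in place of methyl on an oxygen on an aromatic ring. Going by the values given here, none of the measured steps touches this oxygen, so no step bears directly on it, and no shift beyond the scatter is expected in this assay. Compound 4 is therefore expected to give about 15%, between 5% and 30%, which means an estimated step of no change at the digits printed from compound 1 to compound 4 (within the scatter).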

Compound 4, a percentage reported as activity, at one concentration (the size of the read-out at that concentration, not a potency): 100%
Beside the measured number, compound 4's estimate is 85 percentage points below it, and the stated range ends below it.
By their numbers in this assay, from the lowest: compound 1; then compounds 2 and 3 (each within the scatter of the next); then compound 4.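

In this assay this oxygen on an aromatic ring proves a sensitive place: hydrogen in place of methyl gives a number 85 percentage points higher from compound 1 to compound 4 (beyond the scatter) from the loss of a single carbon. The 4-hydroxyphenyl group also stands well clear of both methoxynaphthalene groups, with a number 60 percentage points higher from compound 3 to compound 4 (beyond the scatter) and a number 70 percentage points higher from compound 2 to compound 4 (beyond the scatter) as its steps. Nothing measured here explains this large effect. On these data alone, what stays open is whether the hydroxy group must be free, which an ethoxy group or an amine in its place would test. As far as these compounds go, whether a hydroxy group on the naphthalene would act the same way also remains unknown.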